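A Butyl Chain Enters the Benzyl Group of Compound 2

The source may report more compounds than this note shows. Statements on the series, on what has been measured and on what is new or still open speak of the compounds shown alone.

Compound 1 `CCCCCCCn1ccc2cc(/C(C)=C/C(=O)Nc3ccccc3OCCCC(=O)O)ccc21`, 120 nM
Compound 2 `C/C(=C\C(=O)Nc1ccccc1OCCCC(=O)O)c1ccc2c(ccn2Cc2cccc(C)c2)c1`, 250 nM

In an assay on Prostate gland for inhibition of steroid 5-alpha-reductase (Rattus norvegicus) (a lower number here means a stronger inhibitor, a higher number a weaker inhibitor), compound 2 gives the highest of the two numbers measured; the nearest is compound 1, and the step of a 2.1-fold higher number from compound 1 to compound 2 (0.32 log units; beyond the scatter) lies beyond the scatter. Compound 3 `CCCCc1ccc(Cn2ccc3cc(/C(C)=C/C(=O)Nc4ccccc4OCCCC(=O)O)ccc32)cc1` differs from compound 2 as 4-butylphenyl in place of 3-methylphenyl on a saturated chain carbon bound to an aromatic nitrogen. Among the measured compounds shown here, the only measured step, a 2.1-fold higher number from compound 1 to compound 2 (0.32 log units; beyond the scatter), exchanged a chain for an aromatic ring; no measured step alters a group on that ring, so no direction can be read from it. A step within the scatter is therefore expected, a 1.4-fold lower number from compound 2 to compound 3 (0.14 log units; within the scatter). Compound 3 is estimated at 180 nM, in the range 70 nM to 450 nM.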

Compound 3, half-maximal inhibitory concentration: 100 nM
Compound 3: middle estimate off by 1.8-fold (0.26 log units), on the high side, within the range that was stated.
By their numbers in this assay, from the lowest: compounds 3 and 1 (each within the scatter of the next); then compound 2.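

In this assay the substituent on the benzyl ring proves to matter at this position, with a 2.5-fold lower number from compound 2 to compound 3 (0.40 log units; beyond the scatter) on going from 3-methylbenzyl to 4-butylbenzyl. The aromatic ring itself therefore carries no fixed cost against the hexyl chain, as a 1.2-fold lower number from compound 1 to compound 3 (0.08 log units; within the scatter) shows for the 4-butylphenyl group. Nothing available explains either step. The compounds shown do not separate the effect of the longer butyl chain from that of its different place on the ring, and they leave open what a longer chain or an amine on that ring would give.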